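One Methoxy Group Added, Twice, on Different Cores

The compounds below may be only part of what the source reports. "The series", "measured", "known", "first", "only" and "open" are said of these compounds alone.

Compound 1 `C=C(Br)C(=O)Nc1ccc(/C=C/C(=O)c2ccccc2)cc1` and compound 2 `C=C(Br)C(=O)Nc1ccc(/C=C/C(=O)c2ccc(OC)cc2)cc1` share one core and differ by methoxy in place of hydrogen on an aromatic carbon. In a functional assay on MOLT-4 cells (Homo sapiens) for antiproliferative activity, with a stated time of 48 h (a lower number here means a stronger inhibitor, a higher number a weaker inhibitor), compound 1 gives 3100 nM, and compound 2 gives 1300 nM, a step of a 2.4-fold lower number from compound 1 to compound 2 (0.38 log units; beyond the scatter). Compound 3 `COc1ccccc1/C=C/C(=O)c1ccc(N)cc1` rests on another core; the difference between the two cores is not broken down here. In this assay compound 3 gives 8300 nM. Compound 4 `COc1cccc(/C=C/C(=O)c2ccc(N)cc2)c1OC` is not yet measured and differs from compound 3 by methoxy in place of hydrogen on an aromatic carbon. Around the place the two changes differ: in compound 2 the methoxy stands para to a large group, in compound 4 ortho to a methoxy group and meta to a large group, so this is the same kind of change, not the same. A step of about a 2.1-fold lower number from compound 3 to compound 4 (0.32 log units; beyond the scatter) is expected because of a 2.4-fold lower number from compound 1 to compound 2 (0.38 log units; beyond the scatter), with the different core and surroundings widening the uncertainty. Compound 4 is estimated at 4000 nM, expected between 1500 nM and 10000 nM.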

Compound 4, half-maximal inhibitory concentration: 8500 nM
Compound 4: middle estimate off by 2.1-fold (0.33 log units), on the low side; the range from low to high includes it.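

In this assay, adding the methoxy to compound 3 gives a step of a 1.0-fold higher number from compound 3 to compound 4 (0.01 log units; within the scatter), so on this core the added group leaves no readable mark on the number. Set beside the earlier step, the two cores do not clearly separate: the same change on two cores in this assay, a 2.4-fold lower number (0.38 log units; beyond the scatter) from compound 1 to compound 2 and a 1.0-fold higher number (0.01 log units; within the scatter) from compound 3 to compound 4, 2.4-fold (0.39 log units) apart, within the scatter of two such steps. The drop seen on the first core is thus not visibly repeated, yet with one pair per core and the methoxy in different surroundings, this does not show that the change behaves differently on the two cores, nor that it carries over between them.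

Still open, as far as these compounds go, is whether another group at the same place on compound 3, such as a hydroxy group, an ethoxy group or a chlorine atom, would shift the number.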